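A few compounds are considered here, and "the series" means these few. Any claim that something is new, unique, unknown or untested is made for them only; others in the source may bear on it.

Working notes on the series in an assay on HEK293 cells for binding affinity to 5-hydroxytryptamine receptor 7 (Homo sapiens), read by radioligand binding, tested at 1 uM; a lower number here means less inhibition, a higher number more inhibition at the concentration tested (going by the name of the read-out). Compound 1 `Brc1ccc2ccn(CCN3CCN4CCCC4C3)c2c1` gives 72% in this assay. Compound 2 `Brc1ccc2ccn(CCN3CCC4CCCCN4CC3)c2c1` gives 71% in this assay; the two values lie within the scatter of each other. Compound 3 `CN1CCCN(CCn2ccc3ccc(F)cc32)CC1` gives 60% in this assay, the lowest of the three numbers, with the gaps to compound 2 and to compound 1 both beyond the scatter. Within the data shown here, no single-point step between measured compounds is available: each pair differs in more than one place, so the gaps cannot be assigned to one change.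

Compound 4 `C=C(C)c1ccc2ccn(CCN3CCCN(C)CC3)c2c1` is the next compound for this assay. Against compound 3 the change is 1-methylethenyl in place of fluoro on an aromatic carbon. Among the measured compounds shown here, no measured pair isolates an exchange of this kind, so the size of the step is open. Compounds 1 and 2, which carry bromo rather than fluoro on the core and also differ in the amine part, give the higher numbers, which supports expecting a small rise rather than a fall; the expected step is a number 6 percentage points higher from compound 3 to compound 4 (within the scatter), possibly within the scatter. For compound 4 the estimate in this assay is 66%, expected between 46% and 82%.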

Compound 4, a percentage reported as inhibition, at one concentration (the size of the read-out at that concentration, not a potency): 72%
Beside the measured number, compound 4's estimate is 6 percentage points below it; low and high end bracket the measured number.
By their numbers in this assay, from the lowest: compound 3; then compounds 2, 1 and 4 (each within the scatter of the next).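

Among these compounds, with 1-methylethenyl in place of fluoro on an aromatic carbon, this assay gives a number 12 percentage points higher from compound 3 to compound 4 (beyond the scatter), the first step that can be tied to a single change. The position therefore takes the larger carbon group, with its double bond outside the aromatic rings, without a loss of inhibition at the concentration tested. Nothing available accounts for the rise.

Still open, as far as these compounds go, is whether the double bond matters, which an isopropyl group at the same aromatic carbon would test, and whether a methoxy group or a nitrile would behave like either fluoro or 1-methylethenyl. Among the compounds shown here, also open is whether the step carries over to the amine parts of compound 1 and compound 2, which no single-place pair connects to compound 4.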